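A benzylic swap on the shared core: thiazole to nitrophenyl

The source may hold more compounds than are shown below. What is called first, only, known or untested is meant among the compounds shown, and "the series" means these compounds.

Among the measured compounds shown here, compound 2 `Cc1cc(Nc2nn(Cc3csc(C)n3)c(=O)c3ccccc23)n[nH]1` gives 4180 nM in a functional assay on HCT-116 cells (Homo sapiens) for cytotoxicity, read by CellTiter-Glo, with a stated time of 5 days (a lower number here means a stronger inhibitor, a higher number a weaker inhibitor), the lowest of the two numbers measured so far. For the measured compounds named here, its nearest neighbour, compound 1 `Cc1cc(Nc2nn(Cc3ccncc3)c(=O)c3ccccc23)n[nH]1`, gives 20200 nM in this assay; the only measured step, a 4.8-fold lower number from compound 1 to compound 2 (0.68 log units; beyond the scatter), came from exchanging the group on the saturated chain carbon bound to an aromatic nitrogen. Compound 3 `Cc1cc(Nc2nn(Cc3ccc([N+](=O)[O-])cc3)c(=O)c3ccccc23)n[nH]1` alters the same position once more: 4-nitrophenyl in place of 2-methyl-1,3-thiazol-4-yl on a saturated chain carbon bound to an aromatic nitrogen. Going by the values given here, the single step that bears on this position shows a modest shift when that group is changed, but no measured pair contains the 4-nitrophenyl itself, so the direction is not fixed by the data. Resting on a 4.8-fold lower number from compound 1 to compound 2 (0.68 log units; beyond the scatter) alone, the expectation for compound 3 is a step of a 1.4-fold higher number from compound 2 to compound 3 (0.16 log units; within the scatter). Compound 3 is therefore estimated at 6000 nM, within a range from 1500 nM to 25000 nM.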

Compound 3, half-maximal inhibitory concentration: 1400 nM
Beside the measured number, compound 3's estimate is 4.3-fold (0.63 log units) above it; the whole stated range lies above it.
By their numbers in this assay, from the lowest: compound 3; then compound 2; then compound 1.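

Replacing 2-methyl-1,3-thiazol-4-yl with 4-nitrophenyl on the saturated chain carbon bound to an aromatic nitrogen gives, in this assay, a 3.0-fold lower number from compound 2 to compound 3 (0.48 log units; beyond the scatter) and shows that the thiazole does not mark the low end of this position. Measured against pyridin-4-yl, the same group gives a 14-fold lower number from compound 1 to compound 3 (1.16 log units; beyond the scatter) and turns a modest span at this one place into a large one, with all three groups now ordered by steps beyond the scatter. No measurement at hand accounts for this order.

The compounds shown do not separate the nitro group from the phenyl ring that carries it, and a plain phenyl, or a phenyl bearing an amine or a carboxylic acid instead, would be needed to tell them apart. Going by these compounds, whether a longer chain carrying the 4-nitrophenyl would hold this level also stays open.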